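The compounds below may be only part of what the source reports. "The series", "measured", "known", "first", "only" and "open" are said of these compounds alone.

Compound 1 `COc1ccc(C(=O)/C=C/c2cc3ccccc3[nH]c2=O)cc1`: in an ADME assay on MCF7 cells (Homo sapiens) for cytotoxicity, read by sulforhodamine B assay, with a stated time of 24 h (a higher number here means that more compound is tolerated, a lower number that less compound is tolerated), compound 1 gives > 100000 nM, a limit of the assay.
Compound 2 `O=C(/C=C/c1cc2ccccc2[nH]c1=O)c1ccc(O)cc1`: in this assay compound 2 gives 82900 nM.

Among the measured compounds shown here, compound 2 holds the only number measured; the other value is a limit (the limit of > 100000 nM in this assay, at which 1 of the 2 values shown sits). For the measured compounds named here, the one measured step, an at least 1.2-fold lower number from compound 1 to compound 2 (0.08 log units; that floor lies within the scatter), comes from hydrogen in place of methyl on an oxygen on an aromatic ring. Compound 3 `O=C(/C=C/c1cc2ccccc2[nH]c1=O)c1ccc(Cl)cc1` differs from compound 2 by chloro in place of hydroxy on an aromatic carbon. Going by the values given here, only that one step bears on this change, and it lay within the scatter, so compound 3 is expected to move by a 1.2-fold lower number from compound 2 to compound 3 (0.07 log units; within the scatter), not beyond the scatter, in this assay. Compound 3 is estimated at 70000 nM, between 30000 nM and 160000 nM.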

Compound 3, concentration lethal to 50% of the cells: > 100000 nM
Compound 3: only a limit was reported (the forecaster's own chance of this, stated with the estimate: 40%); at least 1.4-fold (0.15 log units) between middle value and limit.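

The change from 4-hydroxyphenyl to 4-chlorophenyl gives an at least 1.2-fold higher number from compound 2 to compound 3 (0.08 log units; that floor lies within the scatter), so a second replacement of hydroxy at this position now has a floor on its step, though that floor does not pass the scatter. The step from compound 1 to compound 3 cannot be read, as both values are limits. Compound 3 gives a limit and not a number, which leaves hydroxy as the only one of the three groups here with a measured value: the limit of > 100000 nM in this assay, at which 2 of the 3 values shown sit.

On these data alone, how far the true value of compound 3 lies from its limit stays open. So does how an amine or a carboxylic acid at this position would read in this assay.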